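Isopropyl for Methyl in a Series at the Assay Limit

A few compounds are considered here, and "the series" means these few. Any claim that something is new, unique, unknown or untested is made for them only; others in the source may bear on it.

Compound 2 `Cn1c(/C=C2\SC(=O)N(CC(=O)N3CCOCC3)C2=O)nc2ccccc21` has been tested in a functional assay on PC-3 cells (Homo sapiens) for inhibition, read by MTT assay, with a stated time of 48 h; a higher number here means a weaker inhibitor, a lower number a stronger inhibitor. In this assay compound 2 gives only a limit, > 50000 nM, and no number. Compound 1 `Cn1c(/C=C2\SC(=O)N(CC(=O)Nc3cc(C(C)(C)C)on3)C2=O)nc2ccccc21` likewise gives only a limit in this assay, > 50000 nM. Compound 3 `Cn1c(/C=C2\SC(=O)N(CC(=O)N3CCCCC3)C2=O)nc2ccccc21` also gives only a limit in this assay, > 50000 nM. All three values therefore sit at the limit of > 50000 nM in this assay, at which 3 of the 3 values shown sit, so the steps a step that the two limits leave unreadable from compound 1 to compound 2, a step that the two limits leave unreadable from compound 1 to compound 3 and a step that the two limits leave unreadable from compound 2 to compound 3 cannot be read in size or direction; each of them exchanges the group on the carbonyl carbon and none touches the aromatic nitrogen.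

Compound 4 `CC(C)n1c(/C=C2\SC(=O)N(CC(=O)N3CCOCC3)C2=O)nc2ccccc21` differs from compound 2 by isopropyl in place of methyl on an aromatic nitrogen. Going by the values given here, no measured step bears on this position, so the change carries no readable precedent. Because compound 2 gives only the limit > 50000 nM, compound 4 is expected to remain at the limit as well, and its estimate is 80000 nM with a range from 20000 nM to 300000 nM. The expected step is a step that the limit leaves unreadable from compound 2 to compound 4, most likely again reported only as a limit.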

Compound 4, half-maximal inhibitory concentration: > 50000 nM
Compound 4: no number, only a limit; the forecaster's own chance of this, stated with the estimate: 85%; the middle value lies beyond the limit too.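

Compound 2 and compound 4 each give only a limit in this assay, so the exchange of methyl for isopropyl on the aromatic nitrogen cannot be read in size or direction: the limit of > 50000 nM in this assay, at which 4 of the 4 values shown sit.

The compounds shown leave open whether any group at either changed place gives a measurable value on the shared core.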